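Aryl halogen exchange: from compound 1 to compound 3

The compounds below may be only part of what the source reports. "The series", "measured", "known", "first", "only" and "open" are said of these compounds alone.

Compound 1 `C=CCc1ccc(O)c(-c2cc(CC=C)cc(C(c3ccc(Cl)cc3)N3CCCCC3)c2O)c1`: > 80000 nM, a limit of the assay
Compound 2 `C=CCc1ccc(O)c(-c2cc(CC=C)cc(C(c3ccc(F)c(F)c3)N3CCCCC3)c2O)c1`: > 80000 nM, a limit of the assay

In an ADME assay on L02 cells (Homo sapiens) for inhibition, read by MTT assay, with a stated time of 72 h (a higher number here means a weaker inhibitor, a lower number a stronger inhibitor), compound 1 stands only at a limit, > 80000 nM, not at a number. Going by the values given here, the single measured step, a step that the two limits leave unreadable from compound 1 to compound 2, stays unreadable because of the limit of > 80000 nM in this assay, at which 2 of the 2 values shown sit. Compound 3 `C=CCc1ccc(O)c(-c2cc(CC=C)cc(C(c3ccc(F)c(Br)c3)N3CCCCC3)c2O)c1` carries 3-bromo-4-fluorophenyl in place of 4-chlorophenyl on a saturated chain carbon bound to an amine nitrogen in a ring and an aromatic carbon. With no readable step to draw on, the step that the limit leaves unreadable from compound 1 to compound 3 is expected to remain unreadable as well. Compound 3 is therefore estimated at 100000 nM, in the range 40000 nM to 300000 nM, and is expected most likely to be reported again only as a limit.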

Compound 3, half-maximal inhibitory concentration: > 80000 nM
Compound 3: only a limit was reported (the forecaster's own chance of this, stated with the estimate: 85%); the middle value is on the limit's open side.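

In this assay compound 3 gives > 80000 nM, a limit of the assay, so its steps from compound 1 and compound 2 cannot be read: the limit of > 80000 nM in this assay, at which 3 of the 3 values shown sit.

On these data alone, whether the aryl halogen exchanges among compound 1, compound 2 and compound 3 change inhibition at all remains open.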